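Swapping a chlorophenyl for a naphthyl on the sulfur

The compounds below may be only part of what the source reports. "The series", "measured", "known", "first", "only" and "open" are said of these compounds alone.

Measured compounds:
compound 1, `Nc1ccccc1NC(=O)c1ccc(CSc2nccc(C(F)(F)F)n2)cc1`, 80.6%
compound 2, `Nc1ccccc1NC(=O)/C=C/c1ccc(CSc2ccc(Cl)cc2)cc1`, 16.5%
compound 3, `Nc1ccccc1NC(=O)c1ccc(CSc2ccc(C(F)(F)F)cn2)cc1`, 7.57%

All three were tested in a functional assay on SMMC-7721 cells (Homo sapiens) for inhibition, read by CCK-8 assay, with a stated time of 72 h, tested at 8 uM; a higher number here means more inhibition of growth at the concentration tested, a lower number less inhibition of growth. Compound 1 gives the highest number of the three, while compound 2 and compound 3 lie within the scatter of each other and well beneath compound 1, so compound 2 holds the second place of three only in a formal sense.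

Compound 4, `Nc1ccccc1NC(=O)/C=C/c1ccc(CSc2cccc3ccccc23)cc1`, has not yet been measured. It differs from compound 2 in one place: naphthalen-1-yl in place of 4-chlorophenyl on a sulfur. The 4-chlorophenyl group leaves the sulfur and a naphthalen-1-yl group takes its place, adding a second six-membered aromatic ring of carbon.

Within the data shown here, nothing among the measured compounds shows what such a change does in this assay, so the step of a number 3.5 percentage points higher from compound 2 to compound 4 (within the scatter) is expected to be no larger than the scatter, in either direction. For compound 4 the estimated value is 20%, with a range from 5% to 45%.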

Compound 4, percent growth inhibition at one concentration: 18.3%
Beside the measured number, compound 4's estimate is 1.7 percentage points above it; measured number inside the range.
By their numbers in this assay, from the lowest: compounds 3, 2 and 4 (each within the scatter of the next, the first and the last beyond it); then compound 1.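

Going from the 4-chlorophenyl to the naphthalen-1-yl group on the sulfur gives a number 1.8 percentage points higher from compound 2 to compound 4 (within the scatter) in this assay. Among these compounds, this pair is the first to isolate a single change at this position, and it shows that replacing the chlorine-bearing ring with two six-membered aromatic rings of carbon produces no step that can be told from the scatter. At this one concentration and on this core, the two groups therefore cannot be distinguished. No measurement shown here bears on why they read alike.

From the compounds shown here alone, it remains open whether a methyl group, or a phenyl ring carrying an amine or a carboxylic acid, would read differently on the sulfur. Also open, going by these compounds, is whether the same swap would read alike on the core of compound 1.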